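A few compounds are considered here, and "the series" means these few. Any claim that something is new, unique, unknown or untested is made for them only; others in the source may bear on it.

Measured in a functional assay on LoVo cells (Homo sapiens) for inhibition, read by MTT assay, with a stated time of 48 h (a higher number here means a weaker inhibitor, a lower number a stronger inhibitor), so far:
- compound 1 `COc1ccc(N(C)c2nc(C)nc3ccccc23)cc1OCCCC[Se]C#N` gives 882 nM
- compound 2 `COc1ccc(N(C)c2nc(C)nc3ccccc23)cc1C[Se]C#N` gives 277 nM

Compound 2, at 277 nM, holds the lower of the two numbers in this assay and is thus the stronger inhibitor of the pair. Compound 3 `COc1ccc(N(C)c2nc(C)nc3ccccc23)cc1OCCN` carries a 2-aminoethoxy group in place of the selenium-bearing group of compound 2: a group of 4 heavy atoms (2 carbon, 1 nitrogen, 1 oxygen; no ring) in place of a group of 4 heavy atoms (2 carbon, 1 nitrogen, 1 selenium; no ring), on an aromatic carbon. The site is ortho to a methoxy group.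

Going by the values given here, the only measured step that bears on this change is a 3.2-fold lower number from compound 1 to compound 2 (0.50 log units; beyond the scatter). It is modest but beyond the scatter, and it shows that the number responds to the group at this site. Among the compounds with values here, both groups in that step contain selenium, so the data hold no direct precedent for a group without it. Direction is therefore uncertain, and a cautious lean goes toward a weaker result. The expected outcome in this assay is a 2.2-fold higher number from compound 2 to compound 3 (0.34 log units; beyond the scatter) on a similar scale to the measured step. The estimated value for compound 3 is 600 nM and the expected range runs from 130 nM to 2800 nM in this measurement.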

Compound 3, half-maximal inhibitory concentration: 421 nM
For compound 3 the middle estimate is 1.4-fold (0.15 log units) above the measured one, and the stated range covers the measured number.
By their numbers in this assay, from the lowest: compounds 2 and 3 (each within the scatter of the next); then compound 1.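

In this assay, replacing the selenium-bearing group of compound 2 with 2-aminoethoxy gives a 1.5-fold higher number from compound 2 to compound 3 (0.18 log units; within the scatter), so at this aromatic carbon a group with neither selenium nor a triple bond gives a number within the scatter of compound 2. Set against the longer selenium-bearing chain, the same group gives a 2.1-fold lower number from compound 1 to compound 3 (0.32 log units; beyond the scatter), a modest step that leaves compound 1 with the highest number of the three, while selenium is present in both compound 1 and compound 2 and absent from compound 3. No measurement on hand gives a cause for either step.

Still open, on these data alone, is whether the terminal amine of the 2-aminoethoxy group matters to the number, which a hydroxyl or a methoxy at the end of the same chain would test, along with a longer chain such as 3-aminopropoxy. Also open, as far as these compounds go, is how the number responds when selenium alone is exchanged, as with a thiocyanate or a sulfur analogue of the selenium-bearing chain, and whether a carboxylic acid at this site stays in the same range.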